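The source may report more compounds than this note shows. Statements on the series, on what has been measured and on what is new or still open speak of the compounds shown alone.

Going by the values given here, compound 2 `COc1ccc(CNc2nc3cc(N)cc(N)c3nc2-c2ccccc2)cc1OC` gives the higher of the two numbers measured so far in a functional assay on UO-31 cells (Homo sapiens) for inhibition, read by sulforhodamine B assay, with a stated time of 48 h (on this read-out higher numbers stand for weaker inhibition of growth and lower numbers for stronger inhibition of growth), at 13500 nM, while compound 1 `Nc1cc(N)c2nc(-c3ccccc3)c(NCc3ccc(Cl)c(Cl)c3)nc2c1` gives 4170 nM. Among the compounds with values here, the one measured step, a 3.2-fold higher number from compound 1 to compound 2 (0.51 log units; beyond the scatter), swapped the group sitting on the chain carbon bound to the ring nitrogen. Compound 3 `COc1cc(CNc2nc3cc(N)cc(N)c3nc2-c2ccccc2)cc(OC)c1OC` differs from compound 2 by methoxy in place of hydrogen on an aromatic carbon. Within the data shown here, no measured step adds a third methoxy to this ring, so the only guide is that exchanging dichlorophenyl for dimethoxyphenyl weakened growth inhibition modestly; adding one more methoxy to a ring that already carries two is a smaller change, and no shift beyond the scatter is expected. For compound 3 the expected step is a 1.1-fold higher number from compound 2 to compound 3 (0.05 log units; within the scatter). Compound 3 is estimated at 15000 nM, within a range from 6000 nM to 40000 nM.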

Compound 3, concentration for 50% growth inhibition: 11200 nM
Compound 3: middle estimate off by 1.3-fold (0.13 log units), on the high side; the measured number falls inside the stated range.
By their numbers in this assay, from the lowest: compound 1; then compounds 3 and 2 (each within the scatter of the next).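

In this assay, placing a methoxy on this aromatic carbon, ortho to a methoxy group and meta to a large group, gives a 1.2-fold lower number from compound 2 to compound 3 (0.08 log units; within the scatter), so the two compounds cannot be told apart on this read-out. The earlier step, a 3.2-fold higher number from compound 1 to compound 2 (0.51 log units; beyond the scatter), involved a change of the ring's groups that lay beyond the scatter, whereas this added methoxy, with its two heavy atoms and one hydrogen-bond acceptor, leaves growth inhibition without a measurable shift. No supporting data are available to explain this result.

As far as these compounds go, it remains open whether a hydroxyl or an amine on this same carbon would also leave the number within the scatter. A single methoxy also cannot show whether a larger group, such as a butoxy chain, would be accommodated here as well.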